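A few compounds are considered here, and "the series" means these few. Any claim that something is new, unique, unknown or untested is made for them only; others in the source may bear on it.

The shared core of compound 1, with structure `CCOC(=O)CCO/N=C(/c1ccc(OC)c(OC)c1OC)c1cccc2ccccc12`, carries an oxime ether whose chain ends in an ester. In a functional assay on MDA-MB-231 cells (Homo sapiens) for inhibition, read by sulforhodamine B assay, with a stated time of 48 h (a lower number here means a stronger inhibitor, a higher number a weaker inhibitor), compound 1 gives 15200 nM. Among the two compounds measured, compound 1 has the highest number; the only other compound, compound 2, with structure `COc1ccc(C(O)(Cc2ccccc2)c2cccc3ccccc23)c(OC)c1OC`, gives 4780 nM in this assay, and the gap between the two lies beyond the scatter, so compound 2 is the stronger inhibitor of the pair. Compound 3, with structure `CCOC(=O)/C=C/CO/N=C(/c1ccc(OC)c(OC)c1OC)c1cccc2ccccc12`, differs from compound 1 in a single place: 2-(ethoxycarbonyl)ethenyl in place of (ethoxycarbonyl)methyl on a saturated chain carbon bound to an oxygen on an unsaturated carbon. The chain keeps its two hydrogen-bond acceptors and gains one heavy atom together with one more double bond outside the aromatic rings. Within the data shown here, no measured pair shows what such a change does in this assay, and compound 2 differs from compound 1 in several places at once, so it gives no guide here. The step from compound 1 to compound 3 is therefore expected to be small, in either direction or none beyond the scatter, at a 1.3-fold lower number from compound 1 to compound 3 (0.10 log units; within the scatter). Compound 3 is estimated at 12000 nM, within a range from 5000 nM to 30000 nM.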

Compound 3, half-maximal inhibitory concentration: > 20000 nM
Compound 3: only a limit was reported (the forecaster's own chance of this, stated with the estimate: 10%); at least 1.6-fold (0.22 log units) between middle value and limit.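

The first step read at this position, 2-(ethoxycarbonyl)ethenyl in place of (ethoxycarbonyl)methyl on a saturated chain carbon bound to an oxygen on an unsaturated carbon, comes out as an at least 1.3-fold higher number from compound 1 to compound 3 (0.11 log units; that floor lies within the scatter). In this assay, compound 3 is reported only as a limit, > 20000 nM. The change, with its added double bond outside the aromatic rings and its extra heavy atom, therefore yields no stronger inhibitor than the saturated chain, but the floor of the step does not establish a real loss, and the reading stops at a limit: the limit of > 20000 nM in this assay, at which 1 of the 3 values shown sits.

The compounds shown leave open how large this step really is, and whether the double bond or the added chain carbon counts for more, as a saturated chain of the same length would separate the two. They also leave open what happens at the end of the chain if the ester gives way to a carboxylic acid, an amide or an amine.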